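Methoxyphenyl isomers on the shared core: working notes

The source may report more compounds than this note shows. Statements on the series, on what has been measured and on what is new or still open speak of the compounds shown alone.

Of the compounds shown here, three have been measured so far. In a functional assay on MCF7 cells (Homo sapiens) for antiproliferative activity, read by MTT assay, with a stated time of 72 h (a lower number here means a stronger inhibitor, a higher number a weaker inhibitor), compound 1 `O=C1COc2ccc(-c3cccc(NS(=O)(=O)c4ccc(F)cc4)c3)cc2N1` gives 18300 nM and compound 2 `COc1ccc(N2C(=O)COc3ccc(-c4ccc(O)cc4)cc32)cc1` gives 17300 nM while compound 3 `O=C1COc2ccc(-c3cnc(Cl)c(NS(=O)(=O)c4ccc(F)cc4)c3)cc2N1c1ccc(F)cc1` gives 32600 nM in the same test. Compound 2 stands within the usual scatter of both compound 1 and compound 3, so these values set up no ranking around it.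

The next compound is compound 4 `COc1cccc(N2C(=O)COc3ccc(-c4ccc(O)cc4)cc32)c1`. The change from compound 2 is 3-methoxyphenyl in place of 4-methoxyphenyl on an amide-type nitrogen in a ring with the rest of the structure kept. The two have the same atoms, joined differently.

For the measured compounds named here, no measured pair in this small set isolates a change of this kind, so the data do not show how this assay responds to it. Going by the values given here, the only guide is the narrow spread of the three measured values, with compound 2 at 17300 nM as the anchor. No step beyond the scatter is expected, in either direction. The estimated change is a 1.0-fold higher number from compound 2 to compound 4 (0.02 log units; within the scatter) and that is treated as no real shift. In this assay compound 4 is expected at 18000 nM with an estimated range of 8000 nM to 40000 nM as the working figure.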

Compound 4, half-maximal inhibitory concentration: > 40000 nM
Compound 4 ended at the assay's limit; the forecaster's own chance of this, stated with the estimate: 10%; at least 2.2-fold (0.34 log units) between middle value and limit.
By their numbers in this assay, from the lowest: compounds 2, 1 and 3 (each within the scatter of the next). At a limit, above all of these: compound 4.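

In this assay, compound 4 sits at a limit of the test, > 40000 nM, and this is a limit, not a number. For the compounds shown here, compounds 2 and 4 form the first pair that isolates a single change, 3-methoxyphenyl in place of 4-methoxyphenyl on an amide-type nitrogen in a ring, and the pair gives an at least 2.3-fold higher number from compound 2 to compound 4 (0.36 log units; beyond the scatter), so this position responds to where the methoxy group sits on the phenyl ring even though the atoms and the counted features of the two groups are identical. The step is a lower bound only, and its full size cannot be read from the data: the limit of > 40000 nM in this assay, at which 1 of the 4 values shown sits.

Still open is whether the response at this position depends on the methoxy group itself, since an amine, a carboxylic acid or a longer chain such as ethoxy in its place does not appear among the compounds shown. Also open, as far as these compounds go, is whether moving the methoxy group has the same effect when the rest of the structure differs from that of compound 2, as it does in compound 3.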